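The source may hold more compounds than are shown below. What is called first, only, known or untested is meant among the compounds shown, and "the series" means these compounds.

Working notes on the series.

Compound 1 `CO[C@H]1O[C@@]2(C)CC(=O)[C@H]3C[C@]2(O[C@@H]2O[C@H](COC(=O)c4ccccc4)[C@@H](O)[C@H](O)[C@H]2O)[C@]13COC(=O)c1ccc(O)cc1` is assessed in a functional assay on N9 cells (Mus musculus) for inhibition, with N9 (Homo sapiens) as the target, read by Griess assay, with a stated time of 48 h; on this read-out higher numbers stand for weaker inhibition and lower numbers for stronger inhibition. In this assay compound 1 gives > 100000 nM, which is a limit of the assay and not a number. Compound 2 `CO[C@@H]1C[C@]2(C)OC(=O)[C@]3(COC(=O)c4ccccc4)[C@@H]1C[C@@]23O[C@@H]1O[C@H](CO)[C@@H](O)[C@H](O)[C@H]1O` belongs to the same set. In this assay compound 2 gives > 100000 nM, likewise a limit. For the measured compounds named here, compound 1 therefore stands nowhere on a scale of numbers; (the limit of > 100000 nM in this assay, at which 2 of the 2 values shown sit), so no step between measured compounds can be stated and no size of any change is known.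

Compound 3 `CO[C@H]1O[C@@]2(C)CC(=O)[C@H]3C[C@]2(O[C@@H]2O[C@H](COC(=O)c4ccccc4)[C@@H](O)[C@H](O)[C@H]2O)[C@]13COC(=O)c1ccccc1` differs from compound 1 by hydrogen in place of hydroxy on an aromatic carbon, the (4-hydroxyphenyl)carbonyl group becoming benzoyl.

With both measured values sitting at the limit, no direction and no size of step can be read from the data. The step from compound 1 to compound 3 in this assay is expected to be a step that the limit leaves unreadable from compound 1 to compound 3, that is, none that could be distinguished from the scatter. Compound 3 is expected to give about 150000 nM in this assay, within a range of 50000 nM to 500000 nM, most likely returned as a limit again.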

Compound 3, half-maximal inhibitory concentration: 36200 nM
For compound 3 the middle estimate is 4.1-fold (0.62 log units) above the measured one; measured number outside the range, below it.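

In this assay, for the compounds shown here, the place para to a large group on the six-membered aromatic ring of carbon only is the first where a change can be read: hydrogen in place of hydroxy gives an at least 2.7-fold lower number from compound 1 to compound 3 (0.44 log units; beyond the scatter), which on this read-out means stronger inhibition. Compound 3 is also the first compound shown to return a number and not a limit, so (4-hydroxyphenyl)carbonyl and benzoyl are not equivalent on this shared core. For compound 1 the value is a limit and not a number, so the step sets only a minimum size and its true size stays unknown: the limit of > 100000 nM in this assay, at which 2 of the 3 values shown sit.

The compounds shown leave open whether the number of compound 3 is kept, improved or lost with a methoxy group, a fluorine atom or an amine at the same place, and so whether removing the hydroxy group is what matters or whether other replacements would serve equally. They also leave open whether hydrogen in place of hydroxy gives a step of similar size on any other core, and what lies behind the step.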